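Indole hydroxamates: methoxy for fluoro on the benzoyl ring

The source may hold more compounds than are shown below. What is called first, only, known or untested is meant among the compounds shown, and "the series" means these compounds.

Within the data shown here, compound 2 `O=C(NO)c1ccc(Cn2ccc3cc(C(=O)c4ccc(F)cc4)ccc32)cc1` gives 9.25 nM in an assay on isolated protein for inhibition of protein deacetylase HDAC6 (Homo sapiens) (on this read-out higher numbers stand for weaker inhibition and lower numbers for stronger inhibition), the lowest of the three numbers so far. Compound 1 `COc1ccc(C(=O)c2ccc3c(ccn3Cc3ccc(C(=O)NO)cc3)c2)cc1OC` gives 15.5 nM, and the change a 1.7-fold lower number from compound 1 to compound 2 (0.22 log units; within the scatter) stays within the scatter. Compound 3 `COc1cccc(C(=O)c2ccc3c(ccn3S(=O)(=O)c3cccc(/C=C/C(=O)NO)c3)c2)c1` gives 1810 nM, well beyond the scatter from compound 2. Compound 4 `COc1ccc(C(=O)c2ccc3c(ccn3Cc3ccc(C(=O)NO)cc3)c2)cc1` differs from compound 2 by methoxy in place of fluoro on an aromatic carbon. Among the measured compounds shown here, the only step at the same carbon, a 1.7-fold lower number from compound 1 to compound 2 (0.22 log units; within the scatter), swapped alkoxy for fluoro without moving past the scatter, so no step beyond the scatter is expected here either; nothing shows a single methoxy alone. Compound 4 is therefore expected at 12 nM in this assay, between 5 nM and 30 nM, an estimated 1.3-fold higher number from compound 2 to compound 4 (0.11 log units; within the scatter).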

Compound 4, half-maximal inhibitory concentration: 3.92 nM
Compound 4: middle estimate off by 3.1-fold (0.49 log units), on the high side; the measured number lies below the stated range.
By their numbers in this assay, from the lowest: compound 4; then compounds 2 and 1 (each within the scatter of the next); then compound 3.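

Methoxy in place of fluoro on this aromatic carbon gives a 2.4-fold lower number from compound 2 to compound 4 (0.37 log units; beyond the scatter), so this carbon does respond to a substituent change, which the earlier step within the scatter did not show. Hydrogen in place of the other methoxy gives a 4.0-fold lower number from compound 1 to compound 4 (0.60 log units; beyond the scatter), so the second methoxy of compound 1 goes with weaker inhibition rather than adding to the first. No measurement here accounts for either step. Open, going by these compounds, is whether an ethoxy, a hydroxyl or an amine at this carbon would follow methoxy or fluoro, and whether the order of these groups holds on the core of compound 3.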